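Triazole series: trifluoromethyl to methyl swap, cytotoxicity notes

A few compounds are considered here, and "the series" means these few. Any claim that something is new, unique, unknown or untested is made for them only; others in the source may bear on it.

Measured so far in a functional assay on MCF7 cells (Homo sapiens) for cytotoxicity, read by MTT assay, with a stated time of 4 days; a higher number here means a weaker inhibitor, a lower number a stronger inhibitor:
Compound 1 `C=C1C(=O)[C@]23C[C@@]1(O)CC[C@H]2c1ccc(O)c(C)c1[C@@H]3Cn1cc(-c2ccc(C(F)(F)F)cc2)nn1` gives 1840 nM.
Compound 2 `C=C1C(=O)[C@]23C[C@@]1(O)CC[C@H]2c1ccc(O)c(C)c1[C@@H]3Cn1cc(-c2ccc(C)cc2)nn1` gives 370 nM.
Compound 3 `C=C1C[C@]23C[C@@]1(O)CC[C@@H]2c1cccc(C)c1[C@@H]3Cn1cc(-c2ccc(C(F)(F)F)cc2)nn1` gives only a limit of the assay, > 20000 nM.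

Within the data shown here, the one counted step is methyl in place of trifluoromethyl on an aromatic carbon, which gives a 5.0-fold lower number from compound 1 to compound 2 (0.70 log units; beyond the scatter). The difference between the core of compound 1 and the core of compound 3 is not broken down here; for compound 3 only the limit of > 20000 nM in this assay, at which 1 of the 3 values shown sits, is known.

Compound 4 `C=C1C[C@]23C[C@@]1(O)CC[C@@H]2c1cccc(C)c1[C@@H]3Cn1cc(-c2ccc(C)cc2)nn1` is not yet measured. It differs from compound 3 by methyl in place of trifluoromethyl on an aromatic carbon, the same change as from compound 1 to compound 2, at the same place. In this assay the step is expected to be an at least 1.6-fold lower number from compound 3 to compound 4 (0.22 log units; that floor lies within the scatter), resting on the measured step of a 5.0-fold lower number from compound 1 to compound 2 (0.70 log units; beyond the scatter), though the starting point for compound 3 is only a limit. Compound 4 is therefore estimated at 12000 nM, between 3000 nM and 40000 nM.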

Compound 4, half-maximal inhibitory concentration: > 20000 nM
Compound 4: a limit, no number (the forecaster's own chance of this, stated with the estimate: 45%); middle value at least 1.6-fold (0.22 log units) away from the limit.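

Compound 4, like compound 3, sits at the limit of the assay, so the step between them cannot be read: the limit of > 20000 nM in this assay, at which 2 of the 4 values shown sit.

The compounds shown leave open whether methyl in place of trifluoromethyl changes the number at all on the core of compound 3.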